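Piperazine nitrogen substituent and adenosine A2b binding

This account rests on a few compounds, and the source may have more. Where it says the series, first, only, none or still open, it means among the compounds named here.

Three compounds sharing one core are compared in an assay on CHO cells for displacement of a labelled ligand from adenosine receptor A2b (Homo sapiens), read by scintillation counting, with a stated time of 75 min, in the presence of a further agent that is not named here; on this read-out lower numbers stand for stronger inhibition and higher numbers for weaker inhibition. Compound 3 `CCCn1c(=O)[nH]c2nc(-c3ccc(S(=O)(=O)N4CCN(c5cccc(F)c5)CC4)cc3)[nH]c2c1=O` gives 0.632 nM. Compound 1 `CCCn1c(=O)[nH]c2nc(-c3ccc(S(=O)(=O)N4CCN(c5ccc(Br)cc5)CC4)cc3)[nH]c2c1=O` gives 0.0835 nM, and compound 2 `CCCn1c(=O)[nH]c2nc(-c3ccc(S(=O)(=O)N4CCN(C)CC4)cc3)[nH]c2c1=O` gives 48.2 nM. Compound 3 thus stands second of the three: the step of a 7.6-fold higher number from compound 1 to compound 3 (0.88 log units; beyond the scatter) is modest, while the step of a 76-fold lower number from compound 2 to compound 3 (1.88 log units; beyond the scatter) is large, and the step of a 580-fold higher number from compound 1 to compound 2 (2.76 log units; beyond the scatter) shows the full span between the two aryl groups and the methyl group on the piperazine nitrogen.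

Compound 4 `CCCn1c(=O)[nH]c2nc(-c3ccc(S(=O)(=O)N4CCN(C(C)c5ccccc5)CC4)cc3)[nH]c2c1=O` has not yet been measured in this assay. The change is 1-phenylethyl in place of 3-fluorophenyl on an amine nitrogen in a ring, so an aromatic ring remains attached to that nitrogen but now through a 1-phenylethyl link rather than directly. The steps bearing on it are the large 1>2 and 2>3 steps, which show that an aryl group on this nitrogen far outperforms a methyl, and the modest 1>3 step between two aryl groups. Because compound 2 gives 48.2 nM and compound 3 gives 0.632 nM, compound 4 is expected to fall between them, closer to compound 3, with a step of a 4.7-fold higher number from compound 3 to compound 4 (0.68 log units; beyond the scatter) in this assay. The estimate for compound 4 is 3 nM, within 0.5 nM to 20 nM.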

Compound 4, inhibition constant: 8.34 nM
Compound 4: the middle estimate sits 2.8-fold (0.44 log units) below what was measured, and the stated range covers the measured number.
By their numbers in this assay, from the lowest: compound 1; then compound 3; then compound 4; then compound 2.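

In this assay, an aromatic ring on the amine nitrogen in a ring is not enough on its own to match the two aryl compounds. 1-Phenylethyl carries one six-membered aromatic ring, as 3-fluorophenyl does, yet the change gives a 13-fold higher number from compound 3 to compound 4 (1.12 log units; beyond the scatter), larger than the modest 7.6-fold higher number from compound 1 to compound 3 (0.88 log units; beyond the scatter), and the distance to the 4-bromophenyl compound reaches a 100-fold higher number from compound 1 to compound 4 (2.00 log units; beyond the scatter), while a gain over methyl remains, with a 5.8-fold lower number from compound 2 to compound 4 (0.76 log units; beyond the scatter). Among these compounds, the earlier compounds showed only that aryl groups on this nitrogen far outperform methyl; this result shows that the position also distinguishes a ring held on the nitrogen through a 1-phenylethyl link from one joined to it directly, although the loss of fluorine comes with the same change, and nothing given here accounts for these differences.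

The compounds shown leave open how much of the step belongs to the link and how much to the fluorine, a question that plain phenyl and benzyl on this nitrogen would help to separate. They also leave open how a longer chain such as 2-phenylethyl, or a benzoyl group, would read at this position.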